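The source may report more compounds than this note shows. Statements on the series, on what has been measured and on what is new or still open speak of the compounds shown alone.

In an ADME assay on microsomes from liver (Homo sapiens) for metabolic stability, with a stated time of 60 min, tested at 1 uM (on this read-out lower numbers stand for a less stable compound and higher numbers for a more stable compound), compound 1 (`COc1cc(-c2cnn3cc(OC)c(C(C)C)nc23)ccn1`) gives 40%, compound 2 (`COc1cc(-c2cnn3cc(OC)c(C(C)(C)O)nc23)ccn1`) gives 66%, and compound 3 (`COc1cc(-c2cnn3cc(OC)c([C@@H]4COC(C)(C)C4)nc23)ccn1`) gives 13%, the lowest of the three. Compound 4 (`COc1cc(-c2cnn3cc(OC)c(C4CCCC4)nc23)ccn1`) differs from compound 3 on an aromatic carbon: a group of 5 heavy atoms (5 carbon; one five-membered non-aromatic ring of carbon only) in place of a group of 7 heavy atoms (6 carbon, 1 oxygen; one five-membered non-aromatic ring with 1 hetero atom), on an aromatic carbon. Going by the values given here, the steps that bear on this carbon are a number 27 percentage points lower from compound 1 to compound 3 (beyond the scatter) and a number 53 percentage points lower from compound 2 to compound 3 (beyond the scatter), the second being large, while a number 26 percentage points higher from compound 1 to compound 2 (beyond the scatter) shows how far a hydroxy can shift this assay. None of them exchanges one five-membered ring for another, so compound 3 remains the closest guide. No step beyond the scatter is expected, and the estimated change is a number 7 percentage points higher from compound 3 to compound 4 (within the scatter). Compound 4 is expected at 20%, within an estimated range from 7% to 38%.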

Compound 4, percent of the compound remaining: 32%
Compound 4: middle estimate off by 12 percentage points, on the low side, within the range that was stated.
By their numbers in this assay, from the lowest: compound 3; then compounds 4 and 1 (each within the scatter of the next); then compound 2.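

At this aromatic carbon, in this assay, the two five-membered rings are not interchangeable: a number 19 percentage points higher from compound 3 to compound 4 (beyond the scatter) separates the ring with oxygen from cyclopentyl. Cyclopentyl and isopropyl cannot be told apart, since a number 8 percentage points lower from compound 1 to compound 4 (within the scatter) shows that a carbon ring can replace the open chain here with no change beyond the scatter. The 1-hydroxy-1-methylethyl group remains clearly ahead of cyclopentyl, with a number 34 percentage points lower from compound 2 to compound 4 (beyond the scatter) as a large step.

Nothing at hand explains these differences. Going by these compounds, whether a hydroxy on the cyclopentyl ring, an amine or a carboxylic acid at this carbon would match 1-hydroxy-1-methylethyl remains open.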